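From Hydroxy to Amino on the Aromatic Ring

A few compounds are considered here, and "the series" means these few. Any claim that something is new, unique, unknown or untested is made for them only; others in the source may bear on it.

In a functional assay on B16 cells (Mus musculus) for inhibition (a higher number here means a weaker inhibitor, a lower number a stronger inhibitor), compound 1 `C=CC(=O)OCc1cc(=O)oc2cc(OC)c(OC)cc12` is reported only as a limit, > 10 ug/mL. Compound 2 `COc1ccc(/C=C/C(=O)OCc2cc(=O)oc3cc(OC)c(OC)cc23)cc1` gives 0.96 ug/mL. Compound 3 `COc1cc2oc(=O)cc(COC(=O)/C=C/c3ccc(O)cc3)c2cc1OC` gives 4.15 ug/mL, the higher of the two actual numbers, so it is a weaker inhibitor than compound 2.

The next structure, compound 4 `COc1cc2oc(=O)cc(COC(=O)/C=C/c3ccc(N)cc3)c2cc1OC`, carries amino in place of hydroxy on an aromatic carbon, para to a large group: amino in place of hydroxy on an aromatic carbon. Within the data shown here, two measured steps bear on this. Putting 2-(4-hydroxyphenyl)ethenyl in place of vinyl gave an at least 2.4-fold lower number from compound 1 to compound 3 (0.38 log units; beyond the scatter), so this side group counts for much. Hydrogen in place of methyl on the oxygen at the same place gave a 4.3-fold higher number from compound 2 to compound 3 (0.64 log units; beyond the scatter), a modest step, and the closest guide to how much a change there can move this assay. Among the measured compounds shown here, no amino compound has been measured yet, so a smaller step than that one is expected, leaning toward a lower number and possibly staying within the scatter. The expected step is a 1.4-fold lower number from compound 3 to compound 4 (0.14 log units; within the scatter). Compound 4 is expected at 3 ug/mL, with an estimated range of 1 ug/mL to 9 ug/mL.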

Compound 4, half-maximal inhibitory concentration: > 10 ug/mL
Compound 4: a limit, no number (the forecaster's own chance of this, stated with the estimate: 10%); at least 3.3-fold (0.52 log units) between middle value and limit.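

In this assay, this position proves sensitive to more than the loss of a methyl: exchanging hydroxy for amino, with the same counts of hydrogen-bond donors and acceptors, gave an at least 2.4-fold higher number from compound 3 to compound 4 (0.38 log units; beyond the scatter). Set against the methoxy group of compound 2, the amino group gave an at least 10-fold higher number from compound 2 to compound 4 (1.01 log units; beyond the scatter), so among these three groups at this place methoxy gives the strongest inhibitor and amino the weakest. Compound 4 is itself a limit, and the step from compound 1 to it cannot be read: the limit of > 10 ug/mL in this assay, at which 2 of the 4 values shown sit.

As far as these compounds go, how far the number for compound 4 lies past its limit stays open, so the amino step is bounded but has no size. Also open, from the compounds shown here alone, is how a dimethylamino group, an acetamido group or a carboxylic acid at this place would compare with methoxy.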